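Aminophenyl replaces piperidinyl on the shared core

The source may report more compounds than this note shows. Statements on the series, on what has been measured and on what is new or still open speak of the compounds shown alone.

The series is followed in an assay for inhibition of Indoleamine 2,3-dioxygenase 1 (Homo sapiens), with stated times of 10 min and 60 min, tested at 10 uM; on this read-out higher numbers stand for a stronger effect at the one concentration tested and lower numbers for a weaker effect. Compound 1 `O=[N+]([O-])c1cccc(CNc2cc(C(F)(F)F)cc3[nH]ncc23)c1` gives 45% in this assay. Compound 2 `FC(F)(F)c1cc(NC[C@@H]2CCCCN2)c2cn[nH]c2c1` gives 32% in this assay, the lowest of the two numbers shown; its nearest neighbour is compound 1, whose number lies higher by a gap that is beyond the usual scatter. Among the compounds with values here, no step between two measured compounds that differ in one place is available, so the size of any single change is not known from these data.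

Compound 3 `Nc1cccc(CNc2cc(C(F)(F)F)cc3[nH]ncc23)c1` is not yet measured. It differs from compound 2 in one place: 3-aminophenyl in place of piperidin-2-yl on a saturated chain carbon bound to a nitrogen on an aromatic ring. The group that enters is a six-membered aromatic ring of carbon only bearing one hydrogen-bond donor and one acceptor, without a defined stereocentre, in place of the saturated ring of compound 2.

Within the data shown here, with no measured step to anchor the change, the expectation for compound 3 is a modest move upward, as a number 8 percentage points higher from compound 2 to compound 3 (within the scatter), a step that may not exceed the scatter. Compound 3 is therefore estimated at 40% in this assay, within a range from 20% to 60%.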

Compound 3, a percentage reported as inhibition, at one concentration (the size of the read-out at that concentration, not a potency): 24%
The estimate for compound 3 lay 16 percentage points above the measured number, and the stated range covers the measured number.
By their numbers in this assay, from the lowest: compounds 3 and 2 (each within the scatter of the next); then compound 1.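

In this assay, 3-aminophenyl in place of piperidin-2-yl on a saturated chain carbon bound to a nitrogen on an aromatic ring gives a number 8 percentage points lower from compound 2 to compound 3 (within the scatter), so this read-out does not separate the aromatic ring of carbon only from the saturated ring at this position. Amino in place of nitro on an aromatic carbon gives a number 21 percentage points lower from compound 1 to compound 3 (beyond the scatter), the only step in the series so far that lies beyond the scatter, which shows that the read-out responds to the group carried on the aromatic ring. Nothing available explains either step.

The compounds shown leave open whether this response is specific to nitro, and a nitrile or a carboxylic acid on that same aromatic carbon would show whether other groups stand with nitro or with amino. Also open, from the compounds shown here alone, is whether the defined stereocentre of piperidin-2-yl matters, which the opposite enantiomer of compound 2 would address, and whether a longer chain to either ring moves the read-out beyond the scatter.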